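Extending the ether of a benzamide bile acid receptor agonist

The source may hold more compounds than are shown below. What is called first, only, known or untested is meant among the compounds shown, and "the series" means these compounds.

Measured compounds:
compound 1, `Cc1ccc(NC(=O)c2cccc(C(=O)O)c2)cc1`, > 10000 nM
compound 2, `CCCOc1cccc(C(=O)Nc2cccc(C(=O)O)c2)c1`, 2150 nM
compound 3, `CC(C)COc1ccc(C(=O)Nc2cccc(C(=O)O)c2)cc1`, 357 nM

In an assay on isolated protein for agonist activity at Bile acid receptor (Homo sapiens), read by TR-FRET, with a stated time of 3 h, in the absence of a further agent (a lower number here means that less compound is needed, a higher number that more compound is needed for the effect), compound 1 gives only a limit, > 10000 nM, and no number. Compound 2 gives 2150 nM in this assay. Compound 3, with 357 nM, has the lowest of the two numbers shown; compound 2 is the nearest, with a higher number, and that gap lies beyond the scatter.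

Compound 4, `Cc1cccc(COc2ccc(C(=O)Nc3cccc(C(=O)O)c3)cc2)c1`, differs from compound 3 in one place: 3-methylphenyl in place of isopropyl on a saturated chain carbon bound to an oxygen on an aromatic ring. Cut one bond further out, the change reads isobutoxy to (3-methylbenzyl)oxy. Within the data shown here, no step between two measured compounds tells how such a change acts here. Given that the larger ether of compound 3 goes with the lowest number shown, a modest further lowering is expected for compound 4, of about a 2.4-fold lower number from compound 3 to compound 4 (0.38 log units; beyond the scatter), though a change within the scatter would not surprise. Compound 4 is therefore estimated at 150 nM in this assay, within a range of 40 nM to 600 nM.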

Compound 4, half-maximal effective concentration: 259 nM
The estimate for compound 4 lay 1.7-fold (0.24 log units) below the measured number; measured number inside the range.
By their numbers in this assay, from the lowest: compounds 4 and 3 (each within the scatter of the next); then compound 2. At a limit, above all of these: compound 1.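

In this assay, this position on the saturated chain carbon bound to an oxygen on an aromatic ring accepts 3-methylphenyl in place of isopropyl with no change beyond the scatter: a 1.4-fold lower number from compound 3 to compound 4 (0.14 log units; within the scatter). The earlier compounds shown here did not show this, since none of them carries a ring at this place, and here a group of seven heavy atoms with a six-membered aromatic ring stands where one of three heavy atoms stood, and the number holds. Nothing shown gives a reason why the step is so small.

With a single step at this position, the compounds shown cannot separate the part played by the ring from that of its methyl, which a plain phenyl would address. As far as these compounds go, whether an amine or a carboxylic acid on that ring, or a longer chain in its place, would move the number beyond the scatter also remains open.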